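Cyclohexyl for Phenyl on a Pair of Inactive Amides

The source may hold more compounds than are shown below. What is called first, only, known or untested is meant among the compounds shown, and "the series" means these compounds.

Compound 1 `C=CC1=C(C(=O)NC2CCCCC2)C(c2ccc(OC)cc2)OC1` gives > 100000 nM in a functional assay on A549 cells (Homo sapiens) for cytotoxicity, read by MTT assay, with a stated time of 24 h (a lower number here means a stronger inhibitor, a higher number a weaker inhibitor), which is a limit of the assay rather than a number.
Compound 2 `C=CC1=C(C(=O)Nc2ccccc2)C(c2ccc(F)cc2)OC1` gives > 100000 nM in this assay, again a limit and not a number.

Both measured compounds therefore sit at the same place, (the limit of > 100000 nM in this assay, at which 2 of the 2 values shown sit). For the measured compounds named here, compound 2 stands at that limit, and the only other value shown is a limit too, so no order between the two can be read from these numbers.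

Compound 3 `C=CC1=C(C(=O)NC2CCCCC2)C(c2ccc(F)cc2)OC1` has not yet been measured. It differs from compound 2 in one place: cyclohexyl in place of phenyl on an amide-type nitrogen. Compound 1 already carries a cyclohexyl on its amide nitrogen and gave only a limit, which is the closest guide available. Going by the values given here, no step between measured compounds exists here, so the expectation for the change from compound 2 to compound 3 is a step of no size beyond the scatter in this assay, namely a number no higher from compound 2 to compound 3 (the limit leaves the size open). Compound 3 is accordingly expected to give about 100000 nM, within a range of 30000 nM to 300000 nM, most likely reported once more as a limit.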

Compound 3, half-maximal inhibitory concentration: > 100000 nM
Compound 3: a limit, no number; the forecaster's own chance of this, stated with the estimate: 85%; the middle value sits exactly at the limit.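

No step can be read from compound 2 to compound 3 or from compound 1 to compound 3, because all three compounds give the same limit rather than a number: the limit of > 100000 nM in this assay, at which 3 of the 3 values shown sit. The compounds shown leave open whether cyclohexyl in place of phenyl, or fluoro in place of methoxy, changes the result in this assay at all.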